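From 2-chlorophenyl to 4-chlorophenyl on a shared core

The compounds below may be only part of what the source reports. "The series", "measured", "known", "first", "only" and "open" are said of these compounds alone.

Compound 1 `Cc1nc(C(=O)Nc2ccc(Cl)c(-c3nnc4c(Cl)cccn34)c2)cs1` reaches only the assay limit of > 100000 nM in a functional assay on MDA-MB-231 cells (Homo sapiens) for antiproliferative activity, read by MTT assay, with stated times of 72 h and 4 h; on this read-out higher numbers stand for weaker inhibition and lower numbers for stronger inhibition. Compound 2 `O=C(Nc1ccc(Cl)c(-c2nnc3c(Cl)cccn23)c1)c1ccccc1Cl` gives 59900 nM in this assay.

Compound 2 holds the only number shown; the other value is a limit. Compound 3 `O=C(Nc1ccc(Cl)c(-c2nnc3c(Cl)cccn23)c1)c1ccc(Cl)cc1` differs from it by 4-chlorophenyl in place of 2-chlorophenyl on a carbonyl carbon. Going by the values given here, the one measured step, an at least 1.6-fold lower number from compound 1 to compound 2 (0.22 log units; that floor lies within the scatter), changes a different group and sits at a floor within the scatter, with compound 1 at the limit of > 100000 nM in this assay, at which 1 of the 2 values shown sits; it does not bear on this change. No step beyond the scatter is therefore expected, a 1.2-fold lower number from compound 2 to compound 3 (0.08 log units; within the scatter). Compound 3 is estimated at 50000 nM, between 15000 nM and 150000 nM.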

Compound 3, half-maximal inhibitory concentration: > 100000 nM
Compound 3: no number, only a limit (the forecaster's own chance of this, stated with the estimate: 35%); middle value at least 2.0-fold (0.30 log units) away from the limit.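

Moving the chlorine from 2-chlorophenyl to 4-chlorophenyl on the carbonyl carbon gives an at least 1.6-fold higher number from compound 2 to compound 3 (0.22 log units; that floor lies within the scatter), so this change brings no measurable gain in this assay, and its true size stays unknown. The step between compound 1 and compound 3 cannot be read, since both values are limits. Compound 2 remains the only compound with a number, and the others stand at a limit: the limit of > 100000 nM in this assay, at which 2 of the 3 values shown sit.

Going by these compounds, whether 3-chlorophenyl or an aminophenyl group on that carbonyl carbon would give a number rather than a limit stays open.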